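Replacing Trifluoromethyl with a Carbamoyl Ester Chain

The source may report more compounds than this note shows. Statements on the series, on what has been measured and on what is new or still open speak of the compounds shown alone.

Measured compounds:
compound 1 `Nc1ncnc2c1cnn2-c1ccc(C(F)(F)F)cc1` — a functional assay on SF-268 cells (Homo sapiens) for inhibition, with a stated time of 48 h; a higher number here means a weaker inhibitor of growth, a lower number a stronger inhibitor of growth: "not determined" (no result reported)
compound 2 `CC(=O)OC[C@H]1O[C@@H](Nc2ncnc3c2cnn3-c2ccc(C(=O)O)cc2)[C@H](OC(C)=O)[C@@H](OC(C)=O)[C@@H]1OC(C)=O` — this assay: > 150000 nM

Compound 1 stands without a number in this assay, so it gives no anchor. For compound 2 the value in this assay is only a limit, (the limit of > 150000 nM in this assay, at which 1 of the 2 values shown sits). Compound 3 `COC(=O)CNC(=O)c1ccc(-n2ncc3c(N)ncnc32)cc1` differs from compound 1 in one place, (((methoxycarbonyl)methyl)carbamoyl in place of trifluoromethyl on an aromatic carbon). Among the measured compounds shown here, with no step between measured compounds to lean on, the size and direction of the change in this assay cannot be read from these data, and a weak result like that of compound 2 seems as likely as anything else. Compound 3 is therefore expected to give about 100000 nM in this assay, with a range from 20000 nM to 500000 nM.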

Compound 3, concentration for 50% growth inhibition: > 150000 nM
Compound 3: no number, only a limit; the forecaster's own chance of this, stated with the estimate: 55%; at least 1.5-fold (0.17 log units) between middle value and limit.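

In this assay compound 3 gives > 150000 nM, which is a limit and not a number. Among the compounds shown here, compound 1 has no result in this assay, so no step between compound 1 and compound 3 can be read. On these data alone, how strongly any of the three compounds inhibits growth remains open.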